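The compounds below may be only part of what the source reports. "The series", "measured", "known", "first", "only" and "open" are said of these compounds alone.

Compound 1 `Cc1ccc(S(=O)(=O)n2cc(-c3cc(C(F)(F)F)c(C#N)c(-c4cn(S(=O)(=O)c5ccc(C)cc5)c5ccc(Br)cc45)n3)c3cc(Br)ccc32)cc1` in a functional assay on P388 cells (Mus musculus) for cytotoxicity (on this read-out higher numbers stand for weaker inhibition and lower numbers for stronger inhibition), gives only a limit, > 100000 nM.
Compound 2 `Cc1ccc(S(=O)(=O)n2cc(-c3cc(C(F)(F)F)cc(-c4cn(S(=O)(=O)c5ccc(C)cc5)c5cc(Br)ccc45)n3)c3ccc(Br)cc32)cc1` in this assay gives only a limit, > 100000 nM.
Compound 3 `Cc1ccc(S(=O)(=O)n2cc(-c3cc(C(F)(F)F)cc(-c4cn(S(=O)(=O)c5ccc(C)cc5)c5ccccc45)n3)c3ccccc32)cc1` in this assay gives only a limit, > 100000 nM.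

Compound 2 thus stands on no number: its result is a limit, and the other two values shown are limits as well, so that (the limit of > 100000 nM in this assay, at which 3 of the 3 values shown sit). Among the measured compounds shown here, no step between measured compounds can be drawn from these data. Compound 4 `Cc1ccc(S(=O)(=O)n2cc(-c3cc(C(F)(F)F)c(C#N)c(-c4cn(S(=O)(=O)c5ccc(C)cc5)c5cc(Br)ccc45)n3)c3ccc(Br)cc32)cc1` differs from compound 2 by cyano in place of hydrogen on an aromatic carbon. With every measured value sitting at the limit, no direction can be read from the series, and the step is expected to be none beyond the scatter: a number no higher from compound 2 to compound 4 (the limit leaves the size open). Compound 4 is accordingly estimated at 100000 nM in this assay, with a range from 30000 nM to 300000 nM, and most likely only a limit will again be reported.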

Compound 4, half-maximal inhibitory concentration: > 100000 nM
Compound 4 was reported as a limit (the forecaster's own chance of this, stated with the estimate: 90%); the middle value lies on the limit itself.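

No step can be read from compound 2 to compound 4, because both results are limits: the limit of > 100000 nM in this assay, at which 4 of the 4 values shown sit. The compounds shown leave open whether cyano in place of hydrogen on an aromatic carbon changes cytotoxicity at all.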